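Substituent changes on the shared core: outlook for compound 4

The source may hold more compounds than are shown below. What is called first, only, known or untested is meant among the compounds shown, and "the series" means these compounds.

Compound 1 `CC(C)=CCC[C@]1(C)/C=C/[C@@H](OC(=O)C=C(C)C)[C@](C)(O)/C=C/C(=O)/C(CF)=C\C1` gives 240 nM in a functional assay on MCF7 cells (Homo sapiens) for antiproliferative activity, read by MTT assay, with a stated time of 48 h (on this read-out lower numbers stand for stronger inhibition and higher numbers for weaker inhibition), the second highest of the three numbers measured. Compound 2 `CCN(CC)C/C1=C/C[C@](C)(CCC=C(C)C)/C=C/[C@@H](OC(=O)C=C(C)C)[C@](C)(O)/C=C/C1=O` gives 130 nM and compound 3 `CSC(=S)OC/C1=C/C[C@](C)(CCC=C(C)C)/C=C/[C@@H](OC(=O)C=C(C)C)[C@](C)(O)/C=C/C1=O` gives 900 nM. The step of a 1.8-fold lower number from compound 1 to compound 2 (0.27 log units; within the scatter) stays within the scatter, whereas a 3.8-fold higher number from compound 1 to compound 3 (0.57 log units; beyond the scatter) is modest but beyond it, and a 6.9-fold higher number from compound 2 to compound 3 (0.84 log units; beyond the scatter) likewise.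

Compound 4 `CO/N=C/C1=C/C[C@](C)(CCC=C(C)C)/C=C/[C@@H](OC(=O)C=C(C)C)[C@](C)(O)/C=C/C1=O` has not been measured. Against compound 1 the change is a group of 4 heavy atoms (2 carbon, 1 nitrogen, 1 oxygen; no ring) in place of a group of 2 heavy atoms (1 carbon, 1 fluorine; no ring), on a double-bonded ring carbon. Both measured steps from compound 1 exchange the same fluorine for a larger group; one leaves the number unchanged, the other raises it modestly. Compound 4 is therefore expected to show at most a modest rise, a 1.5-fold higher number from compound 1 to compound 4 (0.16 log units; within the scatter). The estimate for compound 4 is 350 nM, with a range of 150 nM to 800 nM.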

Compound 4, half-maximal inhibitory concentration: 2510 nM
Compound 4: middle estimate off by 7.2-fold (0.86 log units), on the low side; measured number outside the range, above it.
By their numbers in this assay, from the lowest: compounds 2 and 1 (each within the scatter of the next); then compound 3; then compound 4.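

Working from this assay, the earlier changes all sat on a saturated chain carbon, whereas the group in compound 4 brings a double bond outside aromatic rings onto the double-bonded ring carbon, and the number rises sharply (a 10-fold higher number from compound 1 to compound 4 (1.02 log units; beyond the scatter); a 19-fold higher number from compound 2 to compound 4 (1.29 log units; beyond the scatter)). Even the weakest earlier compound does not mark the ceiling for this position (a 2.8-fold higher number from compound 3 to compound 4 (0.45 log units; beyond the scatter)). No measurement bearing on this rise is available.

As far as these compounds go, it remains open whether the double bond or the oxygen-bearing end accounts for the rise. A primary amine or a carboxylic acid on the saturated chain carbon is also untested here.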